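Notes on the step to compound 4 in permeability

The source may report more compounds than this note shows. Statements on the series, on what has been measured and on what is new or still open speak of the compounds shown alone.

Values so far in an ADME assay on MDCK-II cells (Canis lupus familiaris) for permeability (a lower number here means that the compound crosses the layer more slowly, a higher number that the compound crosses the layer faster), for three compounds:
- compound 1 `CC(C)Oc1cc(Oc2ccc(S(C)(=O)=O)cc2)cc(-c2ccnc(=O)[nH]2)c1`: "not determined" (no result reported)
- compound 2 `CC(C)Oc1cc(Oc2ccc(S(C)(=O)=O)cc2)cc(-c2ncc(C(C)C)c(=O)[nH]2)c1`: "not determined" (no result reported)
- compound 3 `COc1cnc(-c2cc(Oc3ccc(S(C)(=O)=O)cc3)cc(OC(C)C)c2)[nH]c1=O`: 3.9 10^-6 cm/s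

Compound 1 has no single number in this assay and so holds no place on the scale, and compound 2 is in the same position. Only compound 3 carries a number. Within the data shown here, no step between measured compounds exists, and no trend can be read from one value.

The open entry is compound 4 `CC(C)Oc1cc(Oc2ccc(S(C)(=O)=O)cc2)cc(-c2ncc(Cl)c(=O)[nH]2)c1`, for which no result is available yet. Its difference from compound 1 is counted as a group of 8 heavy atoms (4 carbon, 2 nitrogen, 1 oxygen, 1 chlorine; one six-membered aromatic ring with 2 hetero atoms) in place of a group of 7 heavy atoms (4 carbon, 2 nitrogen, 1 oxygen; one six-membered aromatic ring with 2 hetero atoms), on an aromatic carbon and amounts to a group that also holds chlorine, in place of the group without it. The group sits on an aromatic carbon of a six-membered aromatic ring of carbon only, meta to an isopropoxy group, and the rest of the core of compound 1 stays as it is.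

The data give no direction for this change, so no step beyond the usual scatter is expected in this assay. Among the measured compounds shown here, the only anchor is compound 3 at 3.9 10^-6 cm/s and the range is kept wide. For compound 4 an estimated value of 4.5 10^-6 cm/s is expected, within a range from 2 10^-6 cm/s to 10 10^-6 cm/s in repeated measurements.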

Compound 4, apparent permeability: 8.3 10^-6 cm/s
For compound 4 the middle estimate is 1.8-fold (0.27 log units) below the measured one; measured number inside the range.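

In this assay, the series now has its first readable step, a 2.1-fold higher number from compound 3 to compound 4 (0.33 log units; beyond the scatter), with chloro in place of methoxy on the same aromatic carbon of the otherwise shared structure. This shows that the read-out responds to the group held at this carbon, which a single value could not show, although the change is modest and rests on one pair, so it sets no pattern beyond compound 3 and compound 4. No measured property in hand accounts for the step, and its cause stays unassigned.

Compound 1 and compound 2 still hold no place on the scale, so the unsubstituted parent and the isopropyl analogue cannot yet be set against chloro or methoxy, and the two substituents alone do not define a trend at this carbon. The compounds shown also leave open where groups such as an amine, a carboxylic acid or a longer alkyl chain at this carbon would fall relative to compound 4, and whether the same exchange would give a similar step if the isopropoxy group were replaced.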